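Replacing trifluoromethyl with 2-fluorophenyl in compound 1

The compounds below may be only part of what the source reports. "The series", "measured", "known", "first", "only" and "open" are said of these compounds alone.

Measured in an ADME assay on HCT-116 cells (Homo sapiens) for cytotoxicity, read by CellTiter-Glo, with a stated time of 72 h; a higher number here means a weaker inhibitor, a lower number a stronger inhibitor:
- compound 1 `CC1CCN(C2CCN(S(=O)(=O)c3cccc(C(F)(F)F)c3)CC2)CC1` gives > 5000 nM as a limit
- compound 2 `Cc1cc(C)c(S(=O)(=O)N2CCN(C3CN4CCC3CC4)CC2)c(C)c1` gives > 5000 nM as a limit
- compound 3 `CC1CCN(C2CCN(S(=O)(=O)c3cnc(Cl)s3)CC2)CC1` gives > 10000 nM as a limit

None of these three results is a number. Going by these compounds, compound 1 stands at > 5000 nM in this assay and this is a limit of the assay, so its true position remains open.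

Going by the values given here, compound 4 `CC1CCN(C2CCN(S(=O)(=O)c3cccc(-c4ccccc4F)c3)CC2)CC1` keeps the core of compound 1 and carries 2-fluorophenyl in place of trifluoromethyl on an aromatic carbon as its one change. Among the compounds with values here, no measured step between two compounds gives a size for this change. In this assay no step beyond the scatter is expected, and the estimated a number no higher from compound 1 to compound 4 (the limit leaves the size open) has no firm direction. Compound 4 is expected near 5000 nM with 1500 nM to 15000 nM as the estimated range.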

Compound 4, half-maximal inhibitory concentration: > 5000 nM
Compound 4: only a limit was reported (the forecaster's own chance of this, stated with the estimate: 60%); the middle value sits exactly at the limit.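

Compound 1 and compound 4 both end at a limit in this assay, so the step between them cannot be read. The compounds shown leave open whether any of them has a measurable potency here, and how far 2-fluorophenyl shifts it from trifluoromethyl.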